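The compounds below may be only part of what the source reports. "The series", "measured", "known", "first", "only" and "open" are said of these compounds alone.

Compound 1, whose structure is `N#CC1=C(N)Oc2c(c3nc4ccccc4nc3c3ccccc23)C12C(=O)N(Cc1cnnn1-c1ccc(N)cc1)c1ccccc12`, carries an amino group on a phenyl ring that hangs from a triazole; compound 2, with the structure `CC(=O)Nc1ccc(-n2nncc2CN2C(=O)C3(C(C#N)=C(N)Oc4c3c3nc5ccccc5nc3c3ccccc43)c3ccccc32)cc1`, carries an acetamido group in the same spot. In an ADME assay on HUVEC cells (Homo sapiens) for antiproliferative activity, read by MTT assay, with a stated time of 48 h (a lower number here means a stronger inhibitor, a higher number a weaker inhibitor), compound 1 gives only a limit of the assay, > 50000 nM. Compound 2 likewise gives only a limit in this assay, > 50000 nM. The step between them, a step that the two limits leave unreadable from compound 1 to compound 2, therefore cannot be sized: both values rest at the limit of > 50000 nM in this assay, at which 2 of the 2 values shown sit, and nothing can be read about whether the acetyl group helped or hurt.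

Compound 3, with the structure `N#CC1=C(N)Oc2c(c3nc4ccccc4nc3c3ccccc23)C12C(=O)N(Cc1cnnn1-c1ccc(S(N)(=O)=O)cc1)c1ccccc12`, is not yet measured. It differs from compound 2 by sulfamoyl in place of acetamido on an aromatic carbon. Going by the values given here, no measured step speaks to this change, since the only step available is the unreadable one above. On the evidence of compound 2 sitting at the limit of > 50000 nM in this assay, at which 2 of the 2 values shown sit, the sulfamoyl compound is expected to stay near that limit as well. The step from compound 2 to compound 3 is expected to be a step that the limit leaves unreadable from compound 2 to compound 3. Compound 3 is thus estimated at 60000 nM, within 15000 nM to 250000 nM.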

Compound 3, half-maximal inhibitory concentration: > 50000 nM
Compound 3: only a limit was reported; the forecaster's own chance of this, stated with the estimate: 75%; the middle value is on the limit's open side.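

In this assay compound 3 also gives only a limit, > 50000 nM. The steps to compound 3 from compound 1 and compound 2 cannot be read, and all three compounds rest at the same point: the limit of > 50000 nM in this assay, at which 3 of the 3 values shown sit. The compounds shown leave open whether amino, acetamido and sulfamoyl differ at all in this activity.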